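The source may hold more compounds than are shown below. What is called first, only, known or untested is meant among the compounds shown, and "the series" means these compounds.

compound 1 `CCOC(=O)c1csc2nc(CN3CCN(Cc4ccccc4)CC3)c(-c3ccc(Br)cc3)n12`: 29500 nM
compound 2 `CCC(=O)NNC(=O)c1csc2ncc(-c3ccc(C)cc3)n12`: 13000 nM
compound 3 `CCCC(=O)NNC(=O)c1csc2ncc(-c3ccc(C)cc3)n12`: 45600 nM

In a functional assay on HeLa cells (Homo sapiens) for antiproliferative activity, read by MTT assay, with a stated time of 72 h (on this read-out higher numbers stand for weaker inhibition and lower numbers for stronger inhibition), compound 3 gives 45600 nM. That number lies within the usual scatter of compound 1 at 29500 nM, so the two cannot be told apart. It is clearly weaker than compound 2, as the measured step shows: a 3.5-fold higher number from compound 2 to compound 3 (0.55 log units; beyond the scatter). The next molecule, compound 4 `CCCC(=O)NNC(=O)c1csc2ncc(-c3ccc(OC)cc3)n12`, changes one place on compound 3: methoxy in place of methyl on an aromatic carbon. This is methoxy in place of methyl on an aromatic carbon, turning 4-methylphenyl into 4-methoxyphenyl.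

Among the compounds with values here, no measured step touches that place. Within the data shown here, the only single-place step, the one from compound 2, is a modest change on a saturated chain, so it says little about an aromatic swap. Compound 1 differs from compound 3 in more than one place and offers no direct guide. With so little evidence, no shift beyond the scatter is expected, and the expected step is a 1.2-fold lower number from compound 3 to compound 4 (0.08 log units; within the scatter). For compound 4 the estimated value is 38000 nM, with an expected range of 14000 nM to 95000 nM.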

Compound 4, half-maximal inhibitory concentration: 43300 nM
Compound 4: the middle estimate sits 1.1-fold (0.06 log units) below what was measured; low and high end bracket the measured number.
By their numbers in this assay, from the lowest: compound 2; then compounds 1, 4 and 3 (each within the scatter of the next).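

The swap of methyl for methoxy on this aromatic carbon gives a 1.1-fold lower number from compound 3 to compound 4 (0.02 log units; within the scatter) in this assay and so does not separate 4-methylphenyl from 4-methoxyphenyl. Among the compounds shown, this is the first comparison at this place on the ring, and adding an oxygen and a hydrogen-bond acceptor there leaves no change that can be told from the scatter while the chain of compound 3 stays the same. Nothing measured here explains why the two groups read alike.

Still open, from the compounds shown here alone, is whether a different group at this place, such as an amine or a carboxylic acid, would shift the number beyond the scatter. Going by these compounds, it is also open whether the same methoxy swap would read alike on the shorter chain of compound 2, which stands clearly apart from compound 3.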